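The compounds below may be only part of what the source reports. "The series", "measured", "known", "first", "only" and "open" are said of these compounds alone.

Of the compounds shown here, two have been measured so far. Compound 1 has the structure `C=C1C[C@]23C[C@@]1(O)CC[C@H]2c1cc(Br)c(O/C=C/C(=O)OC)c(C)c1[C@@H]3C(=O)OC`. In a functional assay on CA46 cells (Homo sapiens) for cytotoxicity, read by luminescence and CellTiter-Glo, with a stated time of 24 h (on this read-out higher numbers stand for weaker inhibition and lower numbers for stronger inhibition), compound 1 gives > 10000 nM, which is a limit of the measurement and not a number. Compound 2 has the structure `C=C1C[C@]23C[C@@]1(O)CC[C@H]2[C@@]12C=C[C@H](O)[C@@](C)(C(=O)O1)[C@H]2[C@@H]3C(=O)OC`. In this assay compound 2 gives > 10000 nM, again a limit rather than a number. So compound 2 stands at the same boundary as the only other value shown, and no step between measured compounds can be described; what is known is summed up by the limit of > 10000 nM in this assay, at which 2 of the 2 values shown sit.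

Compound 3, with the structure `C=C1[C@@H](O)[C@]23C[C@@]1(O)CC[C@H]2[C@@]12C=C[C@H](O)[C@@](C)(C(=O)O1)[C@H]2[C@@H]3C(=O)OC`, is the next to be measured in this assay. It differs from compound 2 in one place: hydroxy in place of hydrogen on a saturated ring carbon. The new group sits on a saturated ring carbon of a five-membered non-aromatic ring of carbon only, part of a fused or bridged system of five rings.

With compound 2 giving only a limit, the expected step is a number no higher from compound 2 to compound 3 (the limit leaves the size open), no larger than the usual scatter. For compound 3 in this assay the estimate is 10000 nM, with a range from 3000 nM to 30000 nM, and the measurement is expected most likely to return a limit once more.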

Compound 3, half-maximal inhibitory concentration: > 10000 nM
Compound 3 ended at the assay's limit; the forecaster's own chance of this, stated with the estimate: 85%; the middle value lies on the limit itself.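

Compound 2 and compound 3 both end at a limit of the measurement rather than a number, so no step can be read for the hydroxy that replaces hydrogen on a saturated ring carbon in this assay. The compounds shown leave open what potency any of them truly has, because all of them stop at one boundary: the limit of > 10000 nM in this assay, at which 3 of the 3 values shown sit.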